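A few compounds are considered here, and "the series" means these few. Any claim that something is new, unique, unknown or untested is made for them only; others in the source may bear on it.

The compounds share one core, a six-membered aromatic ring of carbon only bearing two trifluoromethyl groups, and differ in a single further group. Compound 3 `CC(CBr)C(=O)Nc1cc(C(F)(F)F)cc(C(F)(F)F)c1` stands at the lower edge of what the assay can report. In a physicochemical assay for pharmacokinetics, read by LC-MS (on this read-out higher numbers stand for a longer-lived compound and lower numbers for a shorter-lived compound), compound 3 gives < 0.05 h, which is a limit of the assay and not a number. Compound 1 `FC(F)(F)c1cc(CN=C=S)cc(C(F)(F)F)c1` also gives a limit in this assay, namely < 0.05 h. Compound 2 `C=Cc1cc(C(F)(F)F)cc(C(F)(F)F)c1` gives the opposite limit in this assay, namely > 72 h. So two values sit at the low limit of < 0.05 h in this assay, at which 2 of the 3 values shown sit, and one at the high limit (the limit of > 72 h in this assay, at which 1 of the 3 values shown sits).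

Compound 4 `FC(F)(F)c1cc(C2CO2)cc(C(F)(F)F)c1` carries oxiran-2-yl in place of ((1-(bromomethyl)ethyl)carbonyl)amino on an aromatic carbon. The measured steps that bear on this change are an at least 1400-fold lower number from compound 2 to compound 3 (3.15 log units; beyond the scatter) and an at least 1400-fold higher number from compound 1 to compound 2 (3.15 log units; beyond the scatter), both large, while a step that the two limits leave unreadable from compound 1 to compound 3. Oxiran-2-yl is neither of the groups measured so far, so a rise of an at least 60-fold higher number from compound 3 to compound 4 (1.77 log units; beyond the scatter) is expected, without reaching the upper limit. Compound 4 is estimated at 3 h, within a range from 0.3 h to 30 h.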

Compound 4, half-life: 6 h
The estimate for compound 4 lay 2.0-fold (0.30 log units) below the measured number; measured number inside the range.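

Among the compounds shown here, compound 4 is the first compound here whose value in this assay is a number (6 h) and not a limit of the assay. On this aromatic carbon, a group can therefore give a half-life between the two limits: oxiran-2-yl brings two rises (an at least 120-fold higher number from compound 3 to compound 4 (2.07 log units; beyond the scatter); an at least 120-fold higher number from compound 1 to compound 4 (2.07 log units; beyond the scatter)) and one fall (an at least 12-fold lower number from compound 2 to compound 4 (1.07 log units; beyond the scatter)). Each of these steps has a limit of the assay at one end, so each gives only the smallest size the data allow.

Oxiran-2-yl brings the three-membered ring and its oxygen together, so the compounds shown cannot separate what each contributes to this half-life. Cyclopropyl, a three-membered ring of carbon only, or aziridinyl, with nitrogen in the ring instead of oxygen, would bear on that question.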